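An ethyl group on the piperazine of compound 2

The compounds below may be only part of what the source reports. "The series", "measured", "known", "first", "only" and "open" are said of these compounds alone.

In a functional assay on CCRF-CEM cells for antagonist activity at C-X-C chemokine receptor type 4 (Homo sapiens), read by calcium flux, with stated times of 25 min and 90 s (a higher number here means a weaker inhibitor, a lower number a stronger inhibitor), the measured compounds stand as follows:
compound 1 `c1ccc2c(c1)CN[C@H](CN(CCCN1CCNCC1)[C@H]1CCCc3cccnc31)C2` gives 1150 nM
compound 2 `c1ccc2c(c1)CN[C@@H](CN(CCCN1CCNCC1)[C@H]1CCCc3cccnc31)C2` gives 17 nM
compound 3 `c1cnc2c(c1)CCC[C@@H]2N(CCCN1CCNCC1)Cc1cc2ccccc2cn1` gives 17 nM

Compound 2 and compound 3 give the same number at the digits shown, so no change at the digits printed from compound 2 to compound 3 (within the scatter) lies within the scatter, while compound 1 sits far above both of them. The step of a 68-fold lower number from compound 1 to compound 2 (1.83 log units; beyond the scatter) is large and rests on (the fact that compounds 1 and 2 differ only in the configuration as drawn); the step of a 68-fold lower number from compound 1 to compound 3 (1.83 log units; beyond the scatter) is of the same size and comes from exchanging the partly saturated bicyclic group for its aromatic counterpart.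

Compound 4 `CCN1CCN(CCCN(C[C@H]2Cc3ccccc3CN2)[C@H]2CCCc3cccnc32)CC1` is compound 2 with one change: ethyl in place of hydrogen on an amine nitrogen in a ring. None of the three measured steps touches this ring nitrogen; each of them concerns the other end of the molecule, either the configuration at the saturated ring carbon or the bicyclic group on the chain carbon. The measured steps therefore give no direct guide, and in the absence of any step through this position the expected change is a 1.2-fold higher number from compound 2 to compound 4 (0.07 log units; within the scatter), a step not beyond the scatter in either direction. For compound 4 the estimated value in this assay is 20 nM, with a range from 6 nM to 70 nM.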

Compound 4, half-maximal inhibitory concentration: 33 nM
Compound 4: the middle estimate sits 1.7-fold (0.22 log units) below what was measured; low and high end bracket the measured number.
By their numbers in this assay, from the lowest: compounds 2, 3 and 4 (each within the scatter of the next); then compound 1.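

Among these compounds, this result gives the first reading at the piperazine end of the molecule, since every earlier step concerned the configuration at the saturated ring carbon or the bicyclic group on the chain carbon. In this assay, placing ethyl on the amine nitrogen in the ring gives a 1.9-fold higher number from compound 2 to compound 4 (0.29 log units; within the scatter), so this ring nitrogen need not carry a hydrogen for the number to stay within the scatter of that of compound 2, at least in this one pair, and the position accepts a group of two carbons without a measurable loss. Nothing available here bears on why the ethyl group is accepted at this nitrogen.

The compounds shown leave open how far this acceptance extends, for instance to a longer chain such as butyl, to a benzyl group, or to an acetyl group on the same nitrogen. They also leave open whether ethyl would read the same way on compound 3, which carries isoquinolin-3-yl, or on compound 1, with its opposite configuration at the saturated ring carbon.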